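A few compounds are considered here, and "the series" means these few. Any claim that something is new, unique, unknown or untested is made for them only; others in the source may bear on it.

Compound 1 `Nc1n[nH]c2cc(-c3ccc(=O)n(Cc4cccc(Cl)c4)c3)ccc12`: 11 nM
Compound 2 `Nc1n[nH]c2cc(-c3ccc(=O)n(Cc4cccc(F)c4)c3)ccc12`: 19 nM

For the measured compounds named here, in an assay for inhibition of MAP kinase-interacting serine/threonine-protein kinase 1 (Homo sapiens), read by luminescence and ADP-Glo, with a stated time of 2 h (on this read-out higher numbers stand for weaker inhibition and lower numbers for stronger inhibition), compound 2 gives the higher of these two numbers, with compound 1 as its only neighbour; the step of a 1.7-fold higher number from compound 1 to compound 2 (0.24 log units; within the scatter) lies within the scatter. Compound 3 `Nc1n[nH]c2cc(-c3ccc(=O)n(Cc4cccc(C(F)(F)F)c4)c3)ccc12` differs from compound 2 by trifluoromethyl in place of fluoro on an aromatic carbon. Going by the values given here, the single measured step that touches this position, from chloro to fluoro, was small, so little movement is expected from a change at the same place. Compound 3 is expected to stay close to compound 2, the step of a 1.2-fold higher number from compound 2 to compound 3 (0.06 log units; within the scatter) expected to fall within the scatter. The estimate for compound 3 is 22 nM, in the range 8 nM to 60 nM.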

Compound 3, half-maximal inhibitory concentration: 56 nM
Beside the measured number, compound 3's estimate is 2.5-fold (0.41 log units) below it; measured number inside the range.
By their numbers in this assay, from the lowest: compounds 1 and 2 (each within the scatter of the next); then compound 3.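

In this assay, this position proved less forgiving than the swap between chloro and fluoro suggested: trifluoromethyl, with 4 heavy atoms where fluoro has 1, gives a 2.9-fold higher number from compound 2 to compound 3 (0.47 log units; beyond the scatter), and in place of chloro it gives a 5.1-fold higher number from compound 1 to compound 3 (0.71 log units; beyond the scatter). The group on this aromatic carbon can therefore shift inhibition beyond the scatter, here towards weaker inhibition. Nothing available accounts for this shift. Going by these compounds, it remains open whether a methoxy group, an amine or a carboxylic acid at this place would stay near compound 1 and compound 2 or weaken inhibition as compound 3 does.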